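Acetyl for methylsulfonyl: exposure note on compound 4

This account rests on a few compounds, and the source may have more. Where it says the series, first, only, none or still open, it means among the compounds named here.

Measured compounds:
compound 1 `CCCCN(c1nc2c(NS(C)(=O)=O)cccc2o1)[C@H](C)c1ccc(-c2ccccc2-c2nnn[nH]2)cc1` — 49.9 nM
compound 2 `Cc1ccc(-c2nc(=O)o[nH]2)c(-c2ccc([C@@H](C)N(CC3CC3)c3nc4c(C(=O)O)cccc4o3)cc2)c1` — 2920 nM
compound 3 `CCCCN(c1nc2c(C(=O)O)cccc2o1)[C@H](C)c1ccc(-c2cc(Cl)ccc2-c2nc(=O)o[nH]2)cc1` — 677 nM

In an ADME assay on the whole organism (Macaca fascicularis) for pharmacokinetics, read by LC-MS, using cassette dosing, at a dose of 1 mg/kg by the oral route (on this read-out higher numbers stand for higher exposure at the dose given and lower numbers for lower exposure), compound 1 gives 49.9 nM, the lowest of the three numbers. Compound 3 gives 677 nM and compound 2 gives 2920 nM, both beyond the scatter above compound 1. Compound 4 `CCCCN(c1nc2c(NC(C)=O)cccc2o1)[C@H](C)c1ccc(-c2ccccc2-c2nnn[nH]2)cc1` differs from compound 1 by acetyl in place of methylsulfonyl on a nitrogen on an aromatic ring. For the measured compounds named here, no measured pair carries this change, and compounds 2 and 3 differ from compound 1 in several places at once, so they offer no direct guide to it. The step from compound 1 to compound 4 is expected to be small, a 1.6-fold higher number from compound 1 to compound 4 (0.20 log units; within the scatter), at most a slight rise and possibly within the scatter. Compound 4 is therefore estimated at 80 nM, with a range from 20 nM to 320 nM.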

Compound 4, maximal plasma concentration: 26.6 nM
Compound 4: the middle estimate sits 3.0-fold (0.48 log units) above what was measured; measured number inside the range.
By their numbers in this assay, from the lowest: compounds 4 and 1 (each within the scatter of the next); then compound 3; then compound 2.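

Acetyl in place of methylsulfonyl on a nitrogen on an aromatic ring gives a 1.9-fold lower number from compound 1 to compound 4 (0.27 log units; within the scatter) in this assay and so provides the first single-place comparison in the series. At this position, methanesulfonamido to acetamido does not separate the two compounds on this read-out. No measurement shown offers an explanation for this result.

Still open, from the compounds shown here alone, is whether an unsubstituted amine or a longer acyl chain on that nitrogen would give a step beyond the scatter, with the rest of compound 1 unchanged.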